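Methoxy for Methylamino on the Iodo Nucleoside

This account rests on a few compounds, and the source may have more. Where it says the series, first, only, none or still open, it means among the compounds named here.

Compound 1 `COc1ncnc2c1c(-c1cccs1)cn2[C@@H]1O[C@H](CO)[C@@H](O)[C@H]1O` has been measured in a functional assay on A549 cells (Homo sapiens), read by MTT assay, with a stated time of 72 h (on this read-out higher numbers stand for weaker inhibition and lower numbers for stronger inhibition), where compound 1 gives 4850 nM. Compound 2 `CNc1ncnc2c1c(I)cn2[C@@H]1O[C@H](CO)[C@@H](O)[C@H]1O` in this assay returns only a limit, > 100000 nM, and not a number. Compound 2 therefore stands at the limit of > 100000 nM in this assay, at which 1 of the 2 values shown sits, with nothing finer known about it. Among the measured compounds shown here, compound 1 and compound 2 differ in more than one place, so their two values show only that compound 1 has a measured number while compound 2 does not.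

Compound 3 `COc1ncnc2c1c(I)cn2[C@@H]1O[C@H](CO)[C@@H](O)[C@H]1O` is still to be measured in this assay. Relative to compound 2 the change is methoxy in place of methylamino on an aromatic carbon. For the measured compounds named here, no step between measured compounds covers this change, so its size must be guessed. The step of an at least 3.3-fold lower number from compound 2 to compound 3 (0.52 log units; beyond the scatter) is expected to run toward stronger inhibition and beyond the scatter, because compound 1 also carries the methoxy and gives 4850 nM. Compound 3 is expected in this assay to give about 30000 nM, within a range of 5000 nM to 150000 nM, with a real chance that only a limit is returned.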

Compound 3, half-maximal inhibitory concentration: > 20000 nM
Compound 3 ended at the assay's limit (the forecaster's own chance of this, stated with the estimate: 35%); the middle value is on the limit's open side.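

With methoxy held fixed, iodo in place of thiophen-2-yl in this assay gives an at least 4.1-fold higher number from compound 1 to compound 3 (0.61 log units; beyond the scatter), so methoxy on the shared core does not by itself bring a measured number, and the measured value of compound 1 goes with the thiophen-2-yl group in this pair. Compound 3 returns a limit and not a number: the limit of > 20000 nM in this assay, at which 1 of the 3 values shown sits. Compound 2 also returns a limit, so the step from methylamino to methoxy on the iodo nucleoside cannot be read: the limit of > 100000 nM in this assay, at which 1 of the 3 values shown sits.

The compounds shown leave open whether methoxy or methylamino is the better group in this series, since no readable pair isolates that change, and a methylamino partner carrying thiophen-2-yl would be needed to compare the two groups against a measured number. Also open, from the compounds shown here alone, is whether the step seen with thiophen-2-yl is particular to that group or extends to other aromatic rings at the same carbon, such as phenyl or furan-2-yl.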